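The source may hold more compounds than are shown below. What is called first, only, known or untested is meant among the compounds shown, and "the series" means these compounds.

In a functional assay on MCF7 cells (Homo sapiens) for inhibition, read by sulforhodamine B assay, with a stated time of 72 h (a higher number here means a weaker inhibitor of growth, a lower number a stronger inhibitor of growth), compound 1 (`CNC(=O)/C=C/c1ccncc1-c1ccc2ccccc2c1`) gives 9340 nM. Compound 3 (`CCOC(=O)/C=C/c1ccncc1-c1ccc2cc[nH]c2c1`) gives 6880 nM, which lies within the scatter of the value for compound 1, so these two numbers cannot be told apart. Compound 2 (`CCOC(=O)/C=C/c1ccncc1-c1ccc2[nH]ccc2c1`) returned only a limit, > 10000 nM. Compound 1 therefore stands among compounds with weak growth inhibition, and none of the three shows strong activity.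

Compound 4 (`O=C(O)/C=C/c1ccncc1-c1ccc2ccccc2c1`) keeps the core of compound 1 but carries hydroxy in place of methylamino on a carbonyl carbon. In other words, 2-(methylcarbamoyl)ethenyl becomes 2-carboxyethenyl. Among the measured compounds shown here, no two measured compounds differ in one place only, so the data offer no direct guide to this change. A modest step toward a higher number is expected in this assay, and it may not exceed the scatter. The estimated change is a 1.4-fold higher number from compound 1 to compound 4 (0.14 log units; within the scatter). The expected value for compound 4 is 13000 nM, with an estimated range of 5000 nM to 35000 nM.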

Compound 4, concentration for 50% growth inhibition: > 10000 nM
Compound 4 ended at the assay's limit; the forecaster's own chance of this, stated with the estimate: 55%; the middle value lies beyond the limit too.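

Swapping methylamino for hydroxy on a carbonyl carbon, the only single-place change among the compounds shown, gives an at least 1.0-fold higher number from compound 1 to compound 4 (0.02 log units; that floor lies within the scatter) in this assay. Compound 4 gives > 10000 nM, which is a limit of the assay and not a number. The pair therefore shows no gain in growth inhibition from 2-carboxyethenyl over 2-(methylcarbamoyl)ethenyl, but the true size of the step cannot be read, because the values reach the end of the assay's range: the limit of > 10000 nM in this assay, at which 2 of the 4 values shown sit.

From the compounds shown here alone, how far compound 4 lies past that limit stays open. So does whether a primary amide, a methyl ester or a longer chain on the amide nitrogen at this carbonyl carbon would give a lower number than compound 1.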